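This account rests on a few compounds, and the source may have more. Where it says the series, first, only, none or still open, it means among the compounds named here.

Compound 1, `COc1ccc(-n2ccc(=O)c(C(=O)Nc3ccc(Oc4ccnc5[nH]ccc45)c(F)c3)n2)cc1`, opens the set. In a functional assay on A549 cells (Homo sapiens) for cytotoxicity, read by MTT assay, with a stated time of 72 h (on this read-out higher numbers stand for weaker inhibition and lower numbers for stronger inhibition), compound 1 gives > 60000 nM, which is a limit of the assay rather than a number. Compound 2, `COc1ccc(-n2ccc(=O)c(C(=O)Nc3ccc(Oc4ccnc5c4ccn5C)cc3)n2)cc1`, carries the same amide and core with a different ring on the far end. In this assay compound 2 gives > 60000 nM, again only a limit. Compound 3, `Cn1ccc2c(Oc3ccc(NC(=O)c4nn(-c5ccc(Cl)c(F)c5)ccc4=O)cc3)ccnc21`, differs from compound 2 in the group on the aromatic nitrogen: 4-chloro-3-fluorophenyl in place of 4-methoxyphenyl. In this assay compound 3 gives > 60000 nM, also a limit. Among the compounds with values here, the only single-point comparison, a step that the two limits leave unreadable from compound 2 to compound 3, therefore has no readable size, and the whole picture is summed up by the limit of > 60000 nM in this assay, at which 3 of the 3 values shown sit.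

Compound 4, `COc1ccc(-n2ccc(=O)c(C(=O)Nc3ccc(Oc4ccnc5c4ccn5C)c(F)c3)n2)cc1`, is the one still to be tested. It differs from compound 2 by fluoro in place of hydrogen on an aromatic carbon. Within the data shown here, no measured step bears on this change, and every number in hand is a limit, so no direction can be read from the data. The expected step that the limit leaves unreadable from compound 2 to compound 4 is simply one that stays at the limit. For compound 4 the estimate in this assay is 80000 nM, with a range from 40000 nM to 200000 nM, and most likely the assay will again report only a limit.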

Compound 4, half-maximal inhibitory concentration: > 60000 nM
Compound 4 was reported as a limit; the forecaster's own chance of this, stated with the estimate: 85%; the middle value is on the limit's open side.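

Compound 4 also ends at a limit, so its steps from compound 1 and compound 2 cannot be read, and the set stays where it was: the limit of > 60000 nM in this assay, at which 4 of the 4 values shown sit. Going by these compounds, whether any of these changes shifts the result in this assay remains open.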